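This account rests on a few compounds, and the source may have more. Where it says the series, first, only, none or still open, it means among the compounds named here.

Compound 1, `CCN1CCCC(NC(=O)c2c(OC)cc(C(F)(F)F)cc2C(F)(F)F)(c2ccccc2)C1`, in an assay on cells for inhibition of sodium- and chloride-dependent glycine transporter 1 (Homo sapiens) (on this read-out lower numbers stand for an effect already at smaller amounts and higher numbers for an effect only at larger amounts of compound), compound 1 gives 230 nM.
Compound 2, `COc1cc(C(F)(F)F)cc(C(F)(F)F)c1C(=O)NC1(c2ccccc2)CCCN(C2CCCC2)C1`, in this assay compound 2 gives 270 nM.
Compound 3, `COc1cc(C(F)(F)F)cc(C(F)(F)F)c1C(=O)NC1(c2ccccc2)CCCN(C(C)=O)C1`, in this assay compound 3 gives only a limit, > 10000 nM.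

Among these three, compound 3 stands apart: its result is a limit of the assay rather than a measured number (the limit of > 10000 nM in this assay, at which 1 of the 3 values shown sits). The two steps that lead to it, an at least 43-fold higher number from compound 1 to compound 3 (1.63 log units; beyond the scatter) and an at least 37-fold higher number from compound 2 to compound 3 (1.56 log units; beyond the scatter), each put acetyl on the ring nitrogen in place of an alkyl group and were large, whereas a 1.2-fold higher number from compound 1 to compound 2 (0.07 log units; within the scatter) changed little.

Compound 4, `COc1cc(C(F)(F)F)cc(C(F)(F)F)c1C(=O)NC1(c2ccccc2)CCCN(S(C)(=O)=O)C1`, differs from compound 3 in one place: methylsulfonyl in place of acetyl on an amine nitrogen in a ring. Among the compounds with values here, none of the measured steps exchanges acetyl for another group of this kind, so the change is not directly covered; both steps that end at compound 3 only show that leaving the alkyl groups behind was costly. On that basis compound 4 is expected to stay where compound 3 is, with a number no higher from compound 3 to compound 4 (the limit leaves the size open), a step not beyond the scatter. The estimate for compound 4 is 10000 nM, within 3000 nM to 30000 nM.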

Compound 4, half-maximal effective concentration: > 10000 nM
Compound 4 gave a limit, no number; the forecaster's own chance of this, stated with the estimate: 75%; the middle value sits exactly at the limit.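

In this assay compound 4 gives > 10000 nM, which is a limit of the assay and not a number. Replacing the alkyl groups on the ring nitrogen with methylsulfonyl is a large change, with an at least 43-fold higher number from compound 1 to compound 4 (1.63 log units; beyond the scatter) and an at least 37-fold higher number from compound 2 to compound 4 (1.56 log units; beyond the scatter), so the loss seen with acetyl in compound 3 is not confined to acetyl. The step between compound 3 and compound 4 cannot be read, so acetyl and methylsulfonyl cannot be ranked against each other, since both results sit at the same limit: the limit of > 10000 nM in this assay, at which 2 of the 4 values shown sit.

As far as these compounds go, how far compound 3 and compound 4 lie past that limit remains unknown. From the compounds shown here alone, it is also open whether a ring nitrogen bearing only hydrogen, a longer chain such as butyl, or a benzyl group would behave like ethyl and cyclopentyl or like acetyl and methylsulfonyl.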